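Replacing the Diarylamine of Compound 3 by a Biaryl

The compounds below may be only part of what the source reports. "The series", "measured", "known", "first", "only" and "open" are said of these compounds alone.

Compound 1, `CC(C)=CCC[C@@](C)(/C=C/c1ccccc1)/C=C/c1ccc(O)cc1`, gives > 26000 nM in a functional assay on Raji cells (Homo sapiens) for cytotoxicity, with a stated time of 72 h (on this read-out higher numbers stand for an effect only at larger amounts of compound and lower numbers for an effect already at smaller amounts), which is a limit of the assay.
Compound 2, `C=C[C@@](C)(/C=C/c1ccc(Nc2ccc(OC)c(F)c2)cc1)CCC=C(C)C`, gives > 26000 nM in this assay, again a limit.
Compound 3, `C=C[C@@](C)(/C=C/c1ccc(Nc2ccc(F)c(F)c2)cc1)CCC=C(C)C`, gives > 26000 nM in this assay, also a limit.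

Compound 3 therefore stands only at a limit, as do the other two values, all at the limit of > 26000 nM in this assay, at which 3 of the 3 values shown sit. Going by the values given here, the single step between measured compounds, a step that the two limits leave unreadable from compound 2 to compound 3, cannot be read because both ends are limits. Compound 4, `C=C[C@@](C)(/C=C/c1ccc(-c2cccc(Br)c2)cc1)CCC=C(C)C`, differs from compound 3 by 3-bromophenyl in place of (3,4-difluorophenyl)amino on an aromatic carbon. Among the compounds with values here, no measured step gives a readable size for such a change, so the expectation rests on the limits alone. Compound 4 is expected to remain at the limit, estimated at 30000 nM, ranging from 12000 nM to 100000 nM. The step that the limit leaves unreadable from compound 3 to compound 4 is expected to be none beyond the scatter.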

Compound 4, half-maximal effective concentration: > 26000 nM
Compound 4: only a limit was reported; the forecaster's own chance of this, stated with the estimate: 80%; the middle value is on the limit's open side.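

Compound 4, like compound 3, gives only a limit in this assay, so the step between them cannot be read: the limit of > 26000 nM in this assay, at which 4 of the 4 values shown sit.

The compounds shown leave open which change to the shared core, if any, would give a readable value in this assay.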